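Adding fluoro to the core of compound 1

A few compounds are considered here, and "the series" means these few. Any claim that something is new, unique, unknown or untested is made for them only; others in the source may bear on it.

Measured in a functional assay on HCC 2998 cells (Homo sapiens) for antiproliferative activity; a lower number here means a stronger inhibitor of growth, a higher number a weaker inhibitor of growth:
- compound 1 `Oc1ccc(-c2nc3ccccc3s2)cc1O`: 6990 nM
- compound 2 `COc1ccc(-c2nc3cc(F)ccc3s2)cc1F`: 13700 nM
- compound 3 `COc1ccc(-c2nc3cc(F)ccc3s2)cc1Br`: 3450 nM

Compound 1 lies within the scatter of compound 2, and its number is higher than that of compound 3, though only just beyond the scatter. Compound 4 `Oc1ccc(-c2nc3cc(F)ccc3s2)cc1O` keeps the core of compound 1 but has fluoro in place of hydrogen on an aromatic carbon, on a six-membered aromatic ring of carbon only, part of a fused or bridged system of two rings.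

Among the measured compounds shown here, the only measured step, a 4.0-fold lower number from compound 2 to compound 3 (0.60 log units; beyond the scatter), is a different exchange, bromo in place of fluoro on an aromatic carbon, so it bears on this change only loosely. For the measured compounds named here, compound 2 and compound 3 both carry this fluoro, but no measured pair isolates its addition. In this assay, no step beyond the scatter is therefore expected, and the range stays wide. The estimated step is a 1.3-fold lower number from compound 1 to compound 4 (0.10 log units; within the scatter). Compound 4 is expected at 5500 nM, with an estimated range of 2000 nM to 14000 nM.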

Compound 4, concentration for 50% growth inhibition: 1640 nM
Beside the measured number, compound 4's estimate is 3.4-fold (0.53 log units) above it, outside the stated range (below it).
By their numbers in this assay, from the lowest: compound 4; then compound 3; then compounds 1 and 2 (each within the scatter of the next).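

In this assay, among the compounds shown here, fluoro in place of hydrogen on an aromatic carbon gives a 4.3-fold lower number from compound 1 to compound 4 (0.63 log units; beyond the scatter), the first reading of this addition in a matched pair and a step beyond the scatter. It shows that this carbon of the six-membered aromatic ring, meta to a fused ring and para to a fused ring, is not silent: a single fluoro here lowers the number for growth inhibition on the core of compound 1. Nothing given here accounts for the size of this step.

The compounds shown leave open whether a larger halogen such as chloro, or an amine or a methoxy group, at this same carbon would move the number further, in the same direction or not at all. They also leave open whether adding this fluoro would lower the number to a similar extent with other groups elsewhere on the molecule.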